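Diastereomer of Compound 1 in Rat Liver Microsomes

The source may report more compounds than this note shows. Statements on the series, on what has been measured and on what is new or still open speak of the compounds shown alone.

Measured so far:
Compound 1 `C[C@]1(O)C[C@@](c2cccc(C(F)(F)F)c2)([C@H](O)c2ccccn2)C1`: 317 mL/min/kg
Compound 2 `OC(c1cc(F)ccn1)C1(c2ccc(Cl)c(Cl)c2)CCC1`: 3850 mL/min/kg
Compound 3 `C[C@]1(O)C[C@@](c2cccc(OC(F)(F)F)c2)([C@H](O)c2ccccn2)C1`: 200 mL/min/kg

In an ADME assay on liver for metabolic stability, with Liver microsome (Rattus norvegicus) as the target, read by LC-MS, using microsomes, with a stated time of 5 h (a higher number here means faster removal of the compound, a lower number slower removal), compound 1 stands second highest of the three numbers; its nearest neighbour is compound 3, and the step of a 1.6-fold lower number from compound 1 to compound 3 (0.20 log units; within the scatter) lies within the scatter, while compound 2 sits well above both. Compound 4 `C[C@]1(O)C[C@](c2cccc(C(F)(F)F)c2)([C@H](O)c2ccccn2)C1` differs from compound 1 only in configuration: the two compounds have the same atoms and bonds and differ only in configuration as drawn: 2 of 3 stereo elements differ; a stereocentre at a saturated ring carbon is drawn R in compound 1 and S in compound 4; a stereocentre at a saturated ring carbon is drawn s in compound 1 and r in compound 4. Going by the values given here, no measured step concerns a change of configuration, so the one known step, a 1.6-fold lower number from compound 1 to compound 3 (0.20 log units; within the scatter), gives no direct guide to this change, and there is no basis for expecting a shift beyond the scatter in this assay. Compound 4 is therefore expected to give about 300 mL/min/kg (120 mL/min/kg to 800 mL/min/kg), a step of a 1.1-fold lower number from compound 1 to compound 4 (0.02 log units; within the scatter).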

Compound 4, clearance: 66.7 mL/min/kg
The estimate for compound 4 lay 4.5-fold (0.65 log units) above the measured number, outside the stated range (below it).
By their numbers in this assay, from the lowest: compound 4; then compounds 3 and 1 (each within the scatter of the next); then compound 2.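

In this assay, a change of configuration alone gives a 4.8-fold lower number from compound 1 to compound 4 (0.68 log units; beyond the scatter). Going by these compounds alone, the only earlier step, trifluoromethoxy in place of trifluoromethyl on an aromatic carbon, stayed within the scatter, whereas this step lies beyond it and can be assigned to the two differing stereo elements at saturated ring carbons because no atom or bond changes: the fact that compounds 1 and 4 differ only in the configuration as drawn.

The compounds shown leave open which of the two stereo elements carries the step, and whether the same change holds with trifluoromethoxy, as in compound 3. They also do not show how an amine or a carboxylic acid on the core of compound 4 would behave.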